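A few compounds are considered here, and "the series" means these few. Any claim that something is new, unique, unknown or untested is made for them only; others in the source may bear on it.

Measured compounds:
- compound 1, `O=C(COc1ccc(C(=O)/C=C/c2ccccc2Cl)cc1)N[C@H]1CCOC1=O`: 17400 nM
- compound 2, `O=C1OCC[C@@H]1NC(=S)SCCOc1ccccc1[N+](=O)[O-]`: > 64000 nM

Among the compounds with values here, in a functional assay on MCF7 cells (Homo sapiens) for antiproliferative activity, read by MTT assay, with a stated time of 72 h (a higher number here means a weaker inhibitor, a lower number a stronger inhibitor), compound 1 gives 17400 nM, the only numeric value in the set. For compound 2 this assay reports only > 64000 nM, which is a limit, not a number (the limit of > 64000 nM in this assay, at which 1 of the 2 values shown sits). Compound 1 therefore stands alone as the single measured reference. Compound 3, `O=C(COc1ccc(C(=O)/C=C/c2ccccc2)cc1)N[C@H]1CCOC1=O`, differs from compound 1 by hydrogen in place of chloro on an aromatic carbon. Within the data shown here, no measured step of this kind exists here, so the expected step from compound 1 to compound 3 is a 1.4-fold higher number from compound 1 to compound 3 (0.16 log units; within the scatter), a shift not clearly beyond the scatter, perhaps slightly weaker. Compound 3 is estimated at 25000 nM, range 8000 nM to 80000 nM.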

Compound 3, half-maximal inhibitory concentration: > 64000 nM
Compound 3 gave a limit, no number (the forecaster's own chance of this, stated with the estimate: 20%); at least 2.5-fold (0.40 log units) between middle value and limit.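

On the 2-chlorophenyl group of compound 1, hydrogen in place of chloro gives an at least 3.6-fold higher number from compound 1 to compound 3 (0.56 log units; beyond the scatter) in this assay. Within the data shown here, this is the first readable change, and it shows that this aromatic carbon, ortho to a large group, is not indifferent to substitution. Compound 3 reads > 64000 nM, which is a limit, so the step has only a lower bound: the limit of > 64000 nM in this assay, at which 2 of the 3 values shown sit.

On these data alone, whether chloro is specifically required remains open, since fluoro, methyl, methoxy or an amine at this carbon would test that. Chloro elsewhere on this ring is equally open.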